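Epimer at the chain stereocentre: notes on compound 4

The source may report more compounds than this note shows. Statements on the series, on what has been measured and on what is new or still open speak of the compounds shown alone.

Values in a functional assay on HeLa cells (Homo sapiens) for antiproliferative activity, read by XTT assay, with a stated time of 72 h; on this read-out lower numbers stand for stronger inhibition and higher numbers for weaker inhibition:
- compound 1 `C=C(C)CCC[C@]1(C)C2=CCC[C@](C)(CC(=O)c3ccoc3)[C@H]2CC[C@H]1C`: > 100000 nM (a limit of the assay)
- compound 2 `C=C(C)CCC[C@]1(C)C2=CCC[C@](C)(C[C@H](OC(C)=O)C3=CC(=O)OC3O)[C@H]2CC[C@H]1C`: 2600 nM
- compound 3 `CC(C)=CCC[C@]1(C)C2=CCC[C@](C)(CC(=O)c3ccoc3)[C@H]2CC[C@H]1C`: 54500 nM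

Compound 2 at 2600 nM holds the lower of the two actual numbers, with compound 3 at 54500 nM, a gap beyond the scatter. Compound 4 `C=C(C)CCC[C@]1(C)C2=CCC[C@](C)(C[C@@H](OC(C)=O)C3=CC(=O)OC3O)[C@H]2CC[C@H]1C` is the next to be read in this assay. The change is the two compounds have the same atoms and bonds; at least one stereo element is drawn with a configuration in one of them and without one in the other: 1 of 6 stereo elements differ; a stereocentre at a saturated chain carbon is drawn S in compound 2 and R in compound 4.

Among the measured compounds shown here, only one measured step exists, an at least 1.8-fold lower number from compound 1 to compound 3 (0.26 log units; that floor lies within the scatter), and it rests on (the limit of > 100000 nM in this assay, at which 1 of the 3 values shown sits). It concerns the chain alkene, not this stereocentre, so it gives no direct guide to size. With no measured change of configuration to draw on, no shift beyond the scatter is expected, and the expected step is a 1.2-fold higher number from compound 2 to compound 4 (0.06 log units; within the scatter). The estimate for compound 4 is 3000 nM, with an expected range of 800 nM to 12000 nM.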

Compound 4, half-maximal inhibitory concentration: 3500 nM
Compound 4: middle estimate off by 1.2-fold (0.07 log units), on the low side; the range from low to high includes it.
By their numbers in this assay, from the lowest: compounds 2 and 4 (each within the scatter of the next); then compound 3. At a limit, above all of these: compound 1.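

At this saturated chain carbon in this assay, S and R drawings give a 1.3-fold higher number from compound 2 to compound 4 (0.13 log units; within the scatter), so this change of configuration, unlike the chain alkene change seen earlier, moves the read-out by no more than the usual scatter. Both configurations keep the low-micromolar level that compound 2 alone had shown. One caution applies to this reading: the fact that one of compounds 2 and 4 is drawn with a defined configuration and the other without, at the place where they differ.

Still open, going by these compounds, is how an amine or a free hydroxyl in place of the acetate would read at this carbon, in either configuration.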